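This account rests on a few compounds, and the source may have more. Where it says the series, first, only, none or still open, it means among the compounds named here.

Working notes on the integrin series. Of the compounds shown here, two carry a number so far. Compound 1 `Cc1cc(C)c(S(=O)(=O)N[C@@H](CNC(=O)C2=NO[C@]3(CN[C@H](CNc4ncc[nH]4)C3)C2)C(=O)O)c(C)c1` is the lower of the two in a functional assay for antagonist activity at integrin alpha-5/beta-1 (Homo sapiens), read by ELISA; a higher number here means a weaker inhibitor, a lower number a stronger inhibitor: compound 1 gives 230 nM. Compound 2 `Cc1cc(C)c(S(=O)(=O)N[C@@H](CNC(=O)C2=NO[C@@]3(C2)C[C@@H](CNC2N=CC=N2)N(C(=O)OCc2ccccc2)C3)C(=O)O)c(C)c1` sits well apart from it; in this assay compound 2 gives 1200 nM, a gap beyond the scatter, so compound 1 stands as the stronger inhibitor of the pair measured.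

Compound 3 `COC(=O)N1C[C@@]2(CC(C(=O)NC[C@H](NS(=O)(=O)c3c(C)cc(C)cc3C)C(=O)O)=NO2)C[C@H]1CNc1ncc[nH]1` has not yet been measured. It keeps the shared core of compound 1 and differs in one place: methoxycarbonyl in place of hydrogen on an amine nitrogen in a ring. For the measured compounds named here, no measured pair isolates this exact change. What the two numbers show is that the compound with a free amine nitrogen in that ring, compound 1, is the stronger, while compound 2, which also carries a carbamate on an amine nitrogen in a ring, is weaker. A step toward a higher number is therefore expected, of modest size, because compound 2 gives 1200 nM. The expected step is a 2.2-fold higher number from compound 1 to compound 3 (0.34 log units; beyond the scatter). Compound 3 is estimated at 500 nM, with a range from 200 nM to 1500 nM.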

Compound 3, half-maximal inhibitory concentration: 21 nM
Beside the measured number, compound 3's estimate is 24-fold (1.38 log units) above it; measured number outside the range, below it.
By their numbers in this assay, from the lowest: compound 3; then compound 1; then compound 2.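

Methoxycarbonyl in place of hydrogen on an amine nitrogen in a ring brings a large gain in this assay with an 11-fold lower number from compound 1 to compound 3 (1.04 log units; beyond the scatter) as the step, and this is the first reading of a single change at this position. In this pair, therefore, the hydrogen on that ring nitrogen is not needed for inhibition, and a substituent there, next to the ring atom that bears the ((1H-imidazol-2-yl)amino)methyl group, is not merely tolerated but goes with a much lower number. Compound 2 also carries a carbamate on that nitrogen, but it differs from compound 3 in more than one place, so it cannot be read as a measure of the carbamate alone.

Whether the gain is specific to methoxycarbonyl stays open, since a one-place comparison with ethoxycarbonyl, acetyl, methanesulfonyl or a plain methyl on the same nitrogen of the shared core is not among the compounds shown. Why the step has this size also stays open, with no measurement at hand bearing on it.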